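Hydroxyphenyl Returns to the Sulfonyl Ring

The source may hold more compounds than are shown below. What is called first, only, known or untested is meant among the compounds shown, and "the series" means these compounds.

In an assay on cells for inhibition of HSP60/HSP10 (Homo sapiens), with a stated time of 60 min (a lower number here means a stronger inhibitor, a higher number a weaker inhibitor), three sulfonamides built on the shared core have been examined, and a fourth awaits measurement. Compound 1 `COc1ccc(Cl)cc1S(=O)(=O)Nc1ccc(-c2nc3ccccc3o2)cc1` reaches only the limit of > 100000 nM in this assay. Compound 2 `O=S(=O)(Nc1ccc(-c2nc3ccccc3o2)cc1)c1cccc(O)c1` gives 62000 nM in this assay and is the only one of the three with a number rather than a limit. Compound 3 `O=S(=O)(Nc1ccc(-c2nc3ccccc3o2)cc1)c1ccccc1F` likewise stands at the limit of > 100000 nM in this assay. Two of the three results thus sit at the limit of > 100000 nM in this assay, at which 2 of the 3 values shown sit, so compound 3 cannot be ranked against compound 1, and the step that the two limits leave unreadable from compound 1 to compound 3 stays unreadable. The step from compound 2 onward is readable: an at least 1.6-fold higher number from compound 2 to compound 3 (0.20 log units; that floor lies within the scatter). The new compound 4 `O=S(=O)(Nc1ccc(-c2nc3ccccc3o2)cc1)c1ccc(O)cc1` differs from compound 3 in one place: 4-hydroxyphenyl in place of 2-fluorophenyl on a sulfonyl sulfur. This is close to the reverse of the readable step, a hydroxyphenyl group re-entering where a fluorophenyl group sat, though now as 4-hydroxyphenyl rather than 3-hydroxyphenyl. Because an at least 1.6-fold higher number from compound 2 to compound 3 (0.20 log units; that floor lies within the scatter) was recorded when the hydroxyl left, its return is expected to bring a lower number, of the order of an at least 1.6-fold lower number from compound 3 to compound 4 (0.22 log units; that floor lies within the scatter). Compound 4 is therefore estimated at 60000 nM in this assay, within a range from 20000 nM to 150000 nM, with a real chance that only a limit is reported again.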

Compound 4, half-maximal inhibitory concentration: 78000 nM
The estimate for compound 4 lay 1.3-fold (0.11 log units) below the measured number; measured number inside the range.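

In this assay, the change from 3-hydroxyphenyl to 4-hydroxyphenyl on the sulfonyl sulfur is a 1.3-fold higher number from compound 2 to compound 4 (0.10 log units; within the scatter), so these two hydroxyphenyl groups cannot be told apart here. Set against the two groups without a hydroxyl, 4-hydroxyphenyl gives an at least 1.2-fold lower number from compound 3 to compound 4 (0.10 log units; that floor lies within the scatter) and an at least 1.2-fold lower number from compound 1 to compound 4 (0.10 log units; that floor lies within the scatter), and since both floors lie within the scatter, neither step establishes a real gain in inhibition. Among these four compounds, compound 2 and compound 4, the two carrying a hydroxyphenyl group, now both return numbers, whereas compound 1 and compound 3 each stop at a limit rather than a number, and the true size of both steps stays unknown because of that limit: the limit of > 100000 nM in this assay, at which 2 of the 4 values shown sit.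

The compounds shown leave open whether the hydroxyl is what separates these results, since an aminophenyl or a carboxyphenyl group on the sulfonyl sulfur would test whether other groups behave alike. Going by these compounds alone, they also leave open whether any change at this position can bring a step clearly beyond the scatter, as every number so far stays close to the limit of the assay.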